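Swapping Tert-Butyl for Fluoro in a Urea Series

The source may hold more compounds than are shown below. What is called first, only, known or untested is meant among the compounds shown, and "the series" means these compounds.

Of the compounds shown here, three have so far been tested in an ADME assay on BJ cells (Homo sapiens) for cytotoxicity, with a stated time of 72 h; on this read-out higher numbers stand for an effect only at larger amounts of compound and lower numbers for an effect already at smaller amounts. Compound 1 `COc1cccc(NC(=O)Nc2cc(C)nc3ccccc23)c1` gives 27000 nM in this assay. For compound 2 `Cc1cc(NC(=O)Nc2ccccc2N)c2ccccc2n1` this assay reports only the limit > 25000 nM, not a number. Compound 3 `Cc1cc(NC(=O)Nc2cccc(C(C)(C)C)c2)c2ccccc2n1` likewise gives only the limit > 25000 nM in this assay. Among the measured compounds shown here, the single one-point step among the measured compounds, a step that the limit leaves unreadable from compound 1 to compound 3, stays unreadable because of the limit of > 25000 nM in this assay, at which 2 of the 3 values shown sit. Compound 4 `Cc1cc(NC(=O)Nc2cccc(F)c2)c2ccccc2n1` differs from compound 3 by fluoro in place of tert-butyl on an aromatic carbon. For the measured compounds named here, no measured step bears on this change, so no shift beyond the scatter is expected. The estimated step is a step that the limit leaves unreadable from compound 3 to compound 4. Compound 4 is therefore expected at 30000 nM in this assay, within the range 15000 nM to 80000 nM.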

Compound 4, half-maximal effective concentration: > 25000 nM
Compound 4 ended at the assay's limit; the forecaster's own chance of this, stated with the estimate: 65%; the middle value is on the limit's open side.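

No step from compound 1, compound 2 or compound 3 to compound 4 can be read, because each comparison runs into one assay limit: the limit of > 25000 nM in this assay, at which 3 of the 4 values shown sit.

The compounds shown leave open how far fluoro, tert-butyl or methoxy on the aromatic carbon differ in this assay.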